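Lipophilicity notes: the drawn enantiomer of compound 1

A few compounds are considered here, and "the series" means these few. Any claim that something is new, unique, unknown or untested is made for them only; others in the source may bear on it.

Measured so far:
compound 1 `CNC(=O)c1cc(C(=O)NC2CC2)cn([C@H](C)c2ccccc2)c1=O`: 3.5
compound 2 `CNC(=O)c1cc(C(=O)NC2CC2)n(Cc2ccccc2)n1`: 3.1

In a physicochemical assay for lipophilicity (a lower number here means a more polar compound, a higher number a more lipophilic compound), compound 1 gives 3.5, the highest of the two numbers. The nearest is compound 2, which in this assay gives 3.1, a gap beyond the usual scatter. Among the measured compounds shown here, no pair of measured compounds differs in one place only, so no measured step is available; the two values stand on their own.

Compound 3 `CNC(=O)c1cc(C(=O)NC2CC2)cn([C@@H](C)c2ccccc2)c1=O` remains to be measured in this assay. Against compound 1 the change is the two compounds have the same atoms and bonds and differ only in configuration as drawn: 1 of 1 stereo elements differ; a stereocentre at a saturated chain carbon is drawn R in compound 1 and S in compound 3. With the same atoms and bonds and only the drawn configuration changed, nothing in the measured data points to a shift in this assay in either direction, and no step beyond the scatter is expected. Compound 3 is therefore expected to give 3.5, within 3.2 to 3.8. The expected step is no change at the digits printed from compound 1 to compound 3 (within the scatter).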

Compound 3, distribution coefficient: 3.3
For compound 3 the middle estimate is 0.20 log units above the measured one; the range from low to high includes it.
By their numbers in this assay, from the lowest: compounds 2, 3 and 1 (each within the scatter of the next, the first and the last beyond it).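

In this assay the series now has its first comparison at a single place: inverting the stereocentre at a saturated chain carbon from the R drawn in compound 1 to the S drawn in compound 3 gives a number 0.20 log units lower from compound 1 to compound 3 (within the scatter) and stays inside what repeat measurements would show. This pair therefore gives no basis for preferring either configuration at this position in this assay. The comparison isolates the stereocentre alone, with nothing else available to account for the two readings: the fact that compounds 1 and 3 differ only in the configuration as drawn.

Going by these compounds, whether this indifference to configuration holds with other groups remains open, since the pair covers only the methyl group on this carbon and an unsubstituted phenyl ring. A longer chain in place of that methyl group, or an amine or a carboxylic acid on the phenyl ring, could still separate the two configurations.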